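This account rests on a few compounds, and the source may have more. Where it says the series, first, only, none or still open, it means among the compounds named here.

Two pairs of compounds are followed here, and each pair is joined by the same small change. Compound 1 `Cc1ccc(-c2cc(/C=N/c3ccccc3)on2)cc1` carries a methyl group, and compound 2 `FC(F)(F)c1ccc(-c2cc(/C=N/c3ccccc3)on2)cc1` carries a trifluoromethyl group in its place (trifluoromethyl in place of methyl on an aromatic carbon). In a functional assay on COLO 205 cells (Homo sapiens) for inhibition, read by MTT assay, with a stated time of 24 h (a lower number here means a stronger inhibitor, a higher number a weaker inhibitor), compound 1 gives 28900 nM. In this assay compound 2 gives 41300 nM. The measured step of a 1.4-fold higher number from compound 1 to compound 2 (0.16 log units; within the scatter) is small and falls within the scatter, so the two values cannot be told apart.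

Compound 3 `CCc1cc2ccccc2nc1-c1cc(-c2ccc(C)cc2)no1` is built on a different core, and the difference between the two cores is not broken down here. For compound 3 this assay reports only a limit, not a number, namely > 100000 nM, and this matches the line (the limit of > 100000 nM in this assay, at which 1 of the 3 values shown sits).

Compound 4 `CCc1cc2ccccc2nc1-c1cc(-c2ccc(C(F)(F)F)cc2)no1`, not yet measured, is related to compound 3 by the same change that joins compound 1 to compound 2: trifluoromethyl in place of methyl on an aromatic carbon. The place of the change is described in the same words for both pairs, so the change is taken as the same.

The expectation for compound 4 rests on the step from compound 1 to compound 2, which stayed within the scatter. The step from compound 3 to compound 4 is therefore expected to be about a step that the limit leaves unreadable from compound 3 to compound 4. Since compound 3 already sits at a limit, compound 4 is estimated at 150000 nM, with a range from 60000 nM to 400000 nM, and it is expected that this assay will again report only a limit for compound 4.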

Compound 4, half-maximal inhibitory concentration: > 100000 nM
Compound 4: a limit, no number; the forecaster's own chance of this, stated with the estimate: 80%; the middle value is on the limit's open side.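

In this assay compound 4 gives > 100000 nM, which is a limit and not a number. Compound 3 stands at a limit as well, so no step can be read from compound 3 to compound 4: the limit of > 100000 nM in this assay, at which 2 of the 4 values shown sit.

The compounds shown leave open whether trifluoromethyl in place of methyl makes any difference on the core of compound 3, and how that core compares with the core of compound 1.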